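The source may hold more compounds than are shown below. What is called first, only, known or untested is meant among the compounds shown, and "the series" means these compounds.

In a functional assay on MCF7 cells (Homo sapiens) for inhibition, read by fluorescence, with a stated time of 72 h (on this read-out higher numbers stand for weaker inhibition and lower numbers for stronger inhibition), compound 1 `CC(C)n1cnc2c(NC(=N)N)nc(N)nc21` gives 97200 nM, and compound 2 `CC(C)Cn1cnc2c(NC(=N)N)nc(N)nc21` gives 96600 nM. These two numbers stand level within the scatter, so compound 1 has no separate place on the scale from compound 2. Compound 3 `CC(C)n1cnc2c(N)nc(N)nc21` is reported only as a limit of the assay, > 100000 nM. Read together, the measurements sit close to the limit of > 100000 nM in this assay, at which 1 of the 3 values shown sits.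

Compound 4 `CC[C@@H](N)COc1nc(NC(=N)N)c2ncn(C(C)C)c2n1` has not yet been measured. It differs from compound 1 in one place, with 2-aminobutoxy in place of amino on an aromatic carbon.

Two measured steps start from compound 1. Isobutyl in place of isopropyl on an aromatic nitrogen gives a 1.0-fold lower number from compound 1 to compound 2 (0.00 log units; within the scatter). A hydrogen atom in place of a group on a nitrogen on an aromatic ring gives an at least 1.0-fold higher number from compound 1 to compound 3 (0.01 log units; that floor lies within the scatter). Neither step changes the aromatic carbon that carries the new group, so neither sets a size for the change in compound 4, and any forecast remains loose. With compound 1 at 97200 nM, a change that can still be read in this assay is expected mainly toward a lower number. The expected change is modest: a 2.4-fold lower number from compound 1 to compound 4 (0.39 log units; beyond the scatter). For compound 4 the estimated value is 40000 nM, with an expected range from 10000 nM to 100000 nM.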

Compound 4, half-maximal inhibitory concentration: > 100000 nM
Compound 4: only a limit was reported (the forecaster's own chance of this, stated with the estimate: 20%); middle value at least 2.5-fold (0.39 log units) away from the limit.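

In this assay compound 4 is reported only as a limit, > 100000 nM. Among the compounds shown here, no earlier step touched the aromatic carbon between two ring nitrogen atoms, and 2-aminobutoxy in place of amino at this carbon now gives an at least 1.0-fold higher number from compound 1 to compound 4 (0.01 log units; that floor lies within the scatter), so this change brought no reading of stronger inhibition, though that floor lies within the scatter and does not tell how far compound 4 stands from compound 1. Like the two earlier steps from compound 1, this one gives no separation that can be read on the scale, and the compounds stay pressed against the top of the read-out: the limit of > 100000 nM in this assay, at which 2 of the 4 values shown sit.

Going by these compounds, whether any group on this aromatic carbon can bring a clearly lower number stays open, for example a small methoxy, a hydroxyl, or a longer chain ending in a carboxylic acid. Also open is whether the defined stereocentre of the 2-aminobutoxy group matters at all, as the compounds shown hold only one arrangement of it and its value is a limit.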